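This account rests on a few compounds, and the source may have more. Where it says the series, first, only, none or still open, it means among the compounds named here.

In a functional assay on K562 cells (Homo sapiens) for inhibition, read by MTT assay, with a stated time of 72 h (on this read-out lower numbers stand for stronger inhibition and higher numbers for weaker inhibition), compound 1 (`CO[C@@H]1[C@H]2OC(=O)C[C@H]2O[C@@H]1[C@@H](O)c1ccccc1`) gives 8450 nM. Compound 2 (`CO[C@@H](c1ccccc1)[C@H]1O[C@@H]2CC(=O)O[C@@H]2[C@H]1O`) gives 11500 nM, and these two numbers lie within the usual scatter of repeated measurements, so compound 2 cannot be ranked apart from compound 1. Compound 3 (`CO[C@@H]1[C@H]2OC(=O)C[C@H]2O[C@@H]1[C@@H](OC)c1ccccc1`) has not yet been measured. It differs from compound 2 in one place, methyl in place of hydrogen on an oxygen on a saturated carbon, turning a hydroxy into a methoxy. Among the compounds with values here, no measured pair here differs in just one place, so the data give no direct guide to this change. The expectation rests only on the closeness of compound 1 at 8450 nM and compound 2 at 11500 nM, and no shift beyond the scatter is expected in either direction. The expected move is a 1.2-fold lower number from compound 2 to compound 3 (0.08 log units; within the scatter). For compound 3 the estimate is 9500 nM, with an expected range from 3500 nM to 25000 nM.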

Compound 3, half-maximal inhibitory concentration: 9240 nM
The estimate for compound 3 lay 1.0-fold (0.01 log units) above the measured number; the measured number falls inside the stated range.
By their numbers in this assay, from the lowest: compounds 1, 3 and 2 (each within the scatter of the next).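

Turning a hydroxy into a methoxy can now be read directly in this assay: the change gives a 1.2-fold lower number from compound 2 to compound 3 (0.10 log units; within the scatter) and, on the other oxygen, a 1.1-fold higher number from compound 1 to compound 3 (0.04 log units; within the scatter). Both steps lie within the scatter, so methyl in place of hydrogen on either oxygen produces no shift that can be told apart from repeat-measurement noise, and compound 3, with a methoxy on both, stays in the same range. Nothing shown here offers an explanation for this result.

The compounds shown carry only hydrogen or methyl on these oxygens, so it remains open what a longer chain such as ethyl, or a larger group such as benzyl, would do there. On these data alone, it also remains open whether an amine in place of either oxygen group would move the number beyond the scatter.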